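Removing the ethynyl group from compound 3

The source may report more compounds than this note shows. Statements on the series, on what has been measured and on what is new or still open speak of the compounds shown alone.

Compound 1 `C#Cc1cccc(NC(=O)c2cn(Cc3ccccc3)nn2)c1`: 14500 nM
Compound 2 `C#Cc1cccc(NC(=O)c2cn(CC(=O)OCC)nn2)c1`: 91000 nM
Compound 3 `C#Cc1cccc(NC(=O)c2cn(CCOC(C)=O)nn2)c1`: 25100 nM

All three were tested in a functional assay on B16 cells (Mus musculus) for cytotoxicity, read by MTT assay, with a stated time of 48 h; a lower number here means a stronger inhibitor, a higher number a weaker inhibitor. Compound 3 stands within the scatter of compound 1, with a 1.7-fold higher number from compound 1 to compound 3 (0.24 log units; within the scatter), and clearly apart from compound 2, with a 3.6-fold lower number from compound 2 to compound 3 (0.56 log units; beyond the scatter).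

Compound 4 `CC(=O)OCCn1cc(C(=O)Nc2ccccc2)nn1` differs from compound 3 by one change: hydrogen in place of ethynyl on an aromatic carbon. Among the compounds with values here, all three measured compounds carry ethynyl, so no measured step tests this change. The steps available alter only the group on the saturated chain carbon, and the largest is a 6.3-fold higher number from compound 1 to compound 2 (0.80 log units; beyond the scatter). A step of no more than that modest size is expected, and the data leave its direction open, with a slight lean towards a higher number. The estimated change is a 1.4-fold higher number from compound 3 to compound 4 (0.14 log units; within the scatter). For compound 4 the estimated value is 35000 nM, with an expected range of 12000 nM to 100000 nM.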

Compound 4, half-maximal inhibitory concentration: > 100000 nM
Compound 4: only a limit was reported (the forecaster's own chance of this, stated with the estimate: 10%); middle value at least 2.8-fold (0.45 log units) from the limit.
By their numbers in this assay, from the lowest: compounds 1 and 3 (each within the scatter of the next); then compound 2. At a limit, above all of these: compound 4.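

Compound 4 gives only a limit of the assay, not a number: the limit of > 100000 nM in this assay, at which 1 of the 4 values shown sits. Even so, the step can be read: hydrogen in place of ethynyl gives an at least 3.9-fold higher number from compound 3 to compound 4 (0.60 log units; beyond the scatter). Within the data shown here, this is the first sign that a group at this place, on the aromatic carbon meta to a large group, matters, something compounds sharing ethynyl could not show.

From the compounds shown here alone, whether ethynyl itself is needed stays open, as a methyl group, a chlorine atom or a nitrile at this place could tell. So does whether hydrogen in place of ethynyl would cost as much in compound 1 or compound 2.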